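Adding a tert-butyl group to the cyclohexenyl ring

The source may hold more compounds than are shown below. What is called first, only, known or untested is meant among the compounds shown, and "the series" means these compounds.

Measured compounds:
- Compound 1 `CCCCCc1nc(C(F)(F)F)ccc1CNC(=O)C(C)c1ccc(NS(C)(=O)=O)c(F)c1`: 1 nM
- Compound 2 `CC(C(=O)NCc1ccc(C(F)(F)F)nc1C1CCC(F)(F)CC1)c1ccc(NS(C)(=O)=O)c(F)c1`: 1.5 nM
- Compound 3 `CC(C(=O)NCc1ccc(C(F)(F)F)nc1C1=CCCCC1)c1ccc(NS(C)(=O)=O)c(F)c1`: 0.7 nM

All three were tested in an assay on CHO cells for antagonist activity at transient receptor potential cation channel subfamily V member 1 (Homo sapiens), read by FLIPR and calcium flux; on this read-out lower numbers stand for stronger inhibition and higher numbers for weaker inhibition. Compound 3 shows the lowest of the three numbers, but its gap to compound 1 is within the scatter a 1.4-fold lower number from compound 1 to compound 3 (0.15 log units; within the scatter), so the two cannot be ranked; only the gap to compound 2 is beyond it a 2.1-fold lower number from compound 2 to compound 3 (0.33 log units; beyond the scatter).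

Compound 4 `CC(C(=O)NCc1ccc(C(F)(F)F)nc1C1=CCC(C(C)(C)C)CC1)c1ccc(NS(C)(=O)=O)c(F)c1` differs from compound 3 in one place: tert-butyl in place of hydrogen on a saturated ring carbon. The measured steps all change the group on the same aromatic carbon of the shared core, and each stayed small: a 1.5-fold higher number from compound 1 to compound 2 (0.18 log units; within the scatter) and a 1.4-fold lower number from compound 1 to compound 3 (0.15 log units; within the scatter). None of them adds a branch to a ring that is already there, so they bear on the question only loosely. Because those steps were small a 2.1-fold lower number from compound 2 to compound 3 (0.33 log units; beyond the scatter), no more than a modest step is expected in this assay, with the direction open.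

For compound 4 the expected value is 1.5 nM, in a range from 0.4 nM to 6 nM, which is the estimated step of a 2.1-fold higher number from compound 3 to compound 4 (0.33 log units; beyond the scatter).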

Compound 4, inhibition constant: 0.2 nM
The estimate for compound 4 lay 7.5-fold (0.88 log units) above the measured number; the measured number lies below the stated range.
By their numbers in this assay, from the lowest: compound 4; then compounds 3, 1 and 2 (each within the scatter of the next, the first and the last beyond it).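

On the cyclohexenyl ring, a saturated ring carbon three ring bonds from the ring atom that bears a large group takes a tert-butyl group with no loss in this assay; the number instead falls (a 3.5-fold lower number from compound 3 to compound 4 (0.54 log units; beyond the scatter)). Going by these compounds alone, of the earlier changes, only one step went beyond the scatter, whereas the 4-(tert-butyl)cyclohex-1-en-1-yl group stands clear of both the pentyl group (a 5.0-fold lower number from compound 1 to compound 4 (0.70 log units; beyond the scatter)) and the 4,4-difluorocyclohexyl group (a 7.5-fold lower number from compound 2 to compound 4 (0.88 log units; beyond the scatter)). Nothing shown here explains why this added group lowers the number.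

From the compounds shown here alone, whether a smaller methyl group, an isopropyl group or a hydroxyl group on this ring carbon would give a similar number remains open. So does whether a tert-butyl group would lower the number on a cyclohexyl ring without the double bond.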